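The compounds below may be only part of what the source reports. "The series", "measured", "known", "first", "only" and "open" are said of these compounds alone.

Among the compounds with values here, compound 1 `CCCC(=O)Nc1ccc(N2CCN(c3ccc(OC[C@@H]4CO[C@@](Cn5cncn5)(c5ccc(Cl)cc5Cl)O4)cc3)CC2)cc1` gives 9930 nM in a functional assay on HepG2 cells (Homo sapiens) for inhibition, read by MTT assay, with a stated time of 48 h (on this read-out lower numbers stand for stronger inhibition and higher numbers for weaker inhibition), which is the highest of the three numbers measured so far, although the gaps to the other two compounds are small. Compound 2 `CCC(=O)Nc1ccc(N2CCN(c3ccc(OC[C@@H]4CO[C@@](Cn5cncn5)(c5ccc(Cl)cc5Cl)O4)cc3)CC2)cc1` gives 5460 nM in this assay, and compound 3 `O=C(CCCCc1ccccc1)Nc1ccc(N2CCN(c3ccc(OC[C@@H]4CO[C@@](Cn5cncn5)(c5ccc(Cl)cc5Cl)O4)cc3)CC2)cc1` gives 7010 nM. The steps between them are a 1.8-fold lower number from compound 1 to compound 2 (0.26 log units; within the scatter), a 1.4-fold lower number from compound 1 to compound 3 (0.15 log units; within the scatter) and a 1.3-fold higher number from compound 2 to compound 3 (0.11 log units; within the scatter), so none of the three changes to the amide chain moves the number beyond the scatter.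

Compound 4 `O=C(CCCc1ccccc1)Nc1ccc(N2CCN(c3ccc(OC[C@@H]4CO[C@@](Cn5cncn5)(c5ccc(Cl)cc5Cl)O4)cc3)CC2)cc1` differs from compound 1 in one place: phenyl in place of hydrogen on a saturated chain carbon, three bonds along the chain from a carbonyl carbon. Within the data shown here, the closest precedent is the step from compound 1 to compound 3, where a benzyl group entered at the same chain carbon and the number shifted only a 1.4-fold lower number from compound 1 to compound 3 (0.15 log units; within the scatter); the step from compound 2 to compound 3 with a phenethyl group was likewise a 1.3-fold higher number from compound 2 to compound 3 (0.11 log units; within the scatter). A phenyl group at this position is therefore expected to leave the read-out essentially unchanged, with a 1.3-fold lower number from compound 1 to compound 4 (0.12 log units; within the scatter) and no step beyond the scatter. Compound 4 is estimated at 7500 nM, with a range from 3500 nM to 16000 nM.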

Compound 4, half-maximal inhibitory concentration: 10800 nM
Estimate against measurement, compound 4: 1.4-fold (0.16 log units) below; low and high end bracket the measured number.
By their numbers in this assay, from the lowest: compounds 2, 3, 1 and 4 (each within the scatter of the next).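

Phenyl in place of hydrogen on the saturated chain carbon, three bonds along the chain from the carbonyl carbon, gives a 1.1-fold higher number from compound 1 to compound 4 (0.04 log units; within the scatter), and phenyl in place of benzyl at that carbon gives a 1.5-fold higher number from compound 3 to compound 4 (0.19 log units; within the scatter). Benzyl in place of hydrogen on the saturated chain carbon two bonds along the chain from the carbonyl carbon gives a 2.0-fold higher number from compound 2 to compound 4 (0.30 log units; within the scatter), so in this assay each of these steps stays within the scatter. Taken in pairs, however, the steps show that adding benzyl to the end of the chain does not read the same on both starting chains: the same change on two cores in this assay, a 1.4-fold lower number (0.15 log units; within the scatter) from compound 1 to compound 3 and a 2.0-fold higher number (0.30 log units; within the scatter) from compound 2 to compound 4, 2.8-fold (0.45 log units) apart, beyond the scatter of two such steps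

The compounds shown carry only plain carbon chains, some ending in phenyl, on the amide carbonyl. On these data alone, what an amine or a carboxylic acid at the end of such a chain would do remains open.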